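This account rests on a few compounds, and the source may have more. Where it says the series, first, only, none or still open, it means among the compounds named here.

Working notes on the series.

All three measured compounds share one core and differ only in the aryl group on the carbonyl carbon. Compound 1 `CCN1CCN(c2cc(C)c3cc(NC(=O)c4ccc5ccccc5n4)ccc3n2)CC1` gives 7060 nM in a functional assay on MCF7 cells (Homo sapiens) for antiproliferative activity, read by MTT assay, with a stated time of 72 h; on this read-out higher numbers stand for weaker inhibition and lower numbers for stronger inhibition. Compound 2 `CCN1CCN(c2cc(C)c3cc(NC(=O)c4cccc(F)c4)ccc3n2)CC1` gives 8920 nM in this assay. Compound 3 `CCN1CCN(c2cc(C)c3cc(NC(=O)c4cc(Cl)cc(Cl)c4)ccc3n2)CC1` gives 6090 nM in this assay. Compound 3 stands at the lowest of the three numbers, but its separations from the others, a 1.2-fold lower number from compound 1 to compound 3 (0.06 log units; within the scatter) and a 1.5-fold lower number from compound 2 to compound 3 (0.17 log units; within the scatter), both lie within the scatter, as does a 1.3-fold higher number from compound 1 to compound 2 (0.10 log units; within the scatter); no ordering among the three is supported.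

Compound 4 `CCN1CCN(c2cc(C)c3cc(NC(=O)c4ccccc4Cl)ccc3n2)CC1` is not yet measured. It differs from compound 3 in one place: 2-chlorophenyl in place of 3,5-dichlorophenyl on a carbonyl carbon. For the measured compounds named here, the steps that bear on it are the three aryl exchanges on the carbonyl carbon already made, each of which stayed within the scatter. On that basis the expected step from compound 3 is a 1.1-fold higher number from compound 3 to compound 4 (0.03 log units; within the scatter), i.e. none beyond the scatter, with a wide margin because only three points support it.

Compound 4 is therefore estimated at 6500 nM in this assay, with a range from 2800 nM to 15000 nM.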

Compound 4, half-maximal inhibitory concentration: > 50000 nM
Compound 4: no number, only a limit; the forecaster's own chance of this, stated with the estimate: 5%; at least 7.6-fold (0.88 log units) between middle value and limit.
By their numbers in this assay, from the lowest: compounds 3, 1 and 2 (each within the scatter of the next). At a limit, above all of these: compound 4.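

Compound 4 gives a limit of the assay, not a number: the limit of > 50000 nM in this assay, at which 1 of the 4 values shown sits.

Where the earlier aryl exchanges on the carbonyl carbon all stayed within the scatter, this change goes beyond it, with an at least 8.2-fold higher number from compound 3 to compound 4 (0.91 log units; beyond the scatter), an at least 5.6-fold higher number from compound 2 to compound 4 (0.74 log units; beyond the scatter) and an at least 7.0-fold higher number from compound 1 to compound 4 (0.85 log units; beyond the scatter). The aryl group at this place, on a carbonyl carbon whose other neighbour is an amide-type nitrogen, therefore does matter in this assay: among the four compounds, only 2-chlorophenyl separates from the rest, while 3,5-dichlorophenyl, 3-fluorophenyl and quinolin-2-yl stay within the scatter of one another.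

The compounds shown leave open how far these steps actually reach, as only their lower bounds can be read. They also leave open whether an unsubstituted phenyl, or a phenyl carrying an amine or a carboxylic acid, would stay with compound 1, compound 2 and compound 3 or move with compound 4.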